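A 2-bromophenyl swap on the carbonyl carbon

The source may hold more compounds than are shown below. What is called first, only, known or untested is meant among the compounds shown, and "the series" means these compounds.

- Compound 1 `COc1cccc(C(=O)n2c(-c3cn(C)c4ccc(Br)cc34)nc3ccccc32)c1` gives 17800 nM
- Compound 2 `COc1ccc(C(=O)n2c(-c3cn(C)c4ccc(Br)cc34)nc3ccccc32)cc1OC` gives 9700 nM

In a functional assay on HepG2 cells (Homo sapiens) for inhibition, read by MTT assay, with a stated time of 24 h (a lower number here means a stronger inhibitor of growth, a higher number a weaker inhibitor of growth), compound 2 lies within the scatter of compound 1 and so cannot be ranked against it. For the measured compounds named here, compound 3 `Cn1cc(-c2nc3ccccc3n2C(=O)c2ccccc2Br)c2cc(Br)ccc21` keeps the shared core but carries 2-bromophenyl in place of 3,4-dimethoxyphenyl on a carbonyl carbon as its one change from compound 2. Going by the values given here, the only measured step, a 1.8-fold lower number from compound 1 to compound 2 (0.26 log units; within the scatter) with methoxy in place of hydrogen on an aromatic carbon, lies within the scatter. Among the compounds with values here, no measured compound holds a 2-bromophenyl, so this step is weak guidance, and no step beyond the scatter is expected: the estimate is a 1.2-fold higher number from compound 2 to compound 3 (0.09 log units; within the scatter) in this assay with no firm direction. Compound 3 is expected at 12000 nM with 5000 nM to 30000 nM as the estimated range.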

Compound 3, concentration for 50% growth inhibition: 72100 nM
For compound 3 the middle estimate is 6.0-fold (0.78 log units) below the measured one; measured number outside the range, above it.
By their numbers in this assay, from the lowest: compounds 2 and 1 (each within the scatter of the next); then compound 3.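

Measured by this assay the group on this carbonyl carbon does matter: 2-bromophenyl in place of 3,4-dimethoxyphenyl gives a weaker inhibitor of growth (a 7.4-fold higher number from compound 2 to compound 3 (0.87 log units; beyond the scatter)), and so does 2-bromophenyl in place of 3-methoxyphenyl (a 4.1-fold higher number from compound 1 to compound 3 (0.61 log units; beyond the scatter)). These are the first changes shown here that reach beyond the scatter. No measurement available explains the loss.

As far as these compounds go, it remains open whether the bromine itself or the absence of methoxy drives the change. Plain phenyl, or a phenyl carrying an amine or a carboxylic acid, would help to tell these apart.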